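A few compounds are considered here, and "the series" means these few. Any claim that something is new, unique, unknown or untested is made for them only; others in the source may bear on it.

Compound 1 `Cc1c2c(n3c1CCCN[C@@H](C)[C@H](C)Nc1cc-3ccc1C(N)=O)CC(C)(C)CC2=O` gives 29 nM
Compound 2 `Cc1c2c(n3c1CCCN(C)[C@@H](C)[C@H](C)Nc1cc-3ccc1C(N)=O)CC(C)(C)CC2=O` gives 51 nM

Within the data shown here, in a functional assay on HCT-116 cells (Homo sapiens) for antiproliferative activity (on this read-out lower numbers stand for stronger inhibition and higher numbers for weaker inhibition), compound 2 gives 51 nM and stands within the scatter of compound 1, the only other measured compound. Compound 3 `CC(=O)N1CCCc2c(C)c3c(n2-c2ccc(C(N)=O)c(c2)N[C@@H](C)[C@@H]1C)CC(C)(C)CC3=O` differs from compound 2 by the change acetyl in place of methyl on an amine nitrogen in a ring and so carries acetyl in place of methyl on an amine nitrogen in a ring. Among the measured compounds shown here, one measured step bears on this change, the replacement of hydrogen by methyl on that same nitrogen. For the measured compounds named here, it is a 1.8-fold higher number from compound 1 to compound 2 (0.25 log units; within the scatter) and offers only a thin guide, since no measured compound carries acetyl there. Given a 1.8-fold higher number from compound 1 to compound 2 (0.25 log units; within the scatter) as the sole evidence, no step beyond the scatter is expected in this assay, with a slight lean toward a higher number. The estimated step is a 1.6-fold higher number from compound 2 to compound 3 (0.20 log units; within the scatter) in this expectation. For compound 3 the estimated value is 80 nM with an expected range from 20 nM to 350 nM in all.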

Compound 3, half-maximal inhibitory concentration: 27 nM
The estimate for compound 3 lay 3.0-fold (0.47 log units) above the measured number, and the stated range covers the measured number.
By their numbers in this assay, from the lowest: compounds 3, 1 and 2 (each within the scatter of the next).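

Read in this assay, acetyl in place of methyl on this amine nitrogen gives a 1.9-fold lower number from compound 2 to compound 3 (0.28 log units; within the scatter) and acetyl in place of hydrogen gives a 1.1-fold lower number from compound 1 to compound 3 (0.03 log units; within the scatter). The earlier pair showed only that methyl on this nitrogen stays within the scatter of hydrogen, whereas these steps extend that to acetyl, with its 3 heavy atoms and its hydrogen-bond acceptor, so hydrogen, methyl and acetyl on this ring nitrogen cannot be told apart on this read-out. Nothing measured here explains why the numbers stay so close.

As far as these compounds go, whether a bulkier acyl group such as benzoyl, a longer acyl chain or a carboxylic acid at the end of such a chain would also stay within the scatter remains open. So does whether the same holds with the two ring methyl groups in another arrangement.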